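A few compounds are considered here, and "the series" means these few. Any claim that something is new, unique, unknown or untested is made for them only; others in the source may bear on it.

Series notes. Compound 1 `CC(=O)N(CC(C1CCCCC1)N1CCN(C(=O)[C@@H]2CN(C(C)(C)C)C[C@H]2c2ccc(F)cc2F)CC1)C(C)C` gives 2800 nM in a functional assay on CHO cells for agonist activity at Melanocortin receptor 5 (Homo sapiens), read by cAMP accumulation; a higher number here means that more compound is needed for the effect, a lower number that less compound is needed. Compound 2 `CC(C)N(CC(C1CCCCC1)N1CCN(C(=O)[C@@H]2CN(C(C)(C)C)C[C@H]2c2ccc(F)cc2F)CC1)S(C)(=O)=O` returns only the assay limit of > 5000 nM in this assay. Compound 3 `CC(C)N(CC(C1CCCCC1)N1CCN(C(=O)[C@@H]2CN(C(C)(C)C)C[C@H]2c2ccc(F)cc2F)CC1)C(=O)c1cccnn1` gives 490 nM in this assay, the lowest of the two numbers shown. Both measured steps run toward compound 3: a 5.7-fold lower number from compound 1 to compound 3 (0.76 log units; beyond the scatter) and an at least 10-fold lower number from compound 2 to compound 3 (1.00 log units; beyond the scatter). Compound 4 `CC(C)N(CC(C1CCCCC1)N1CCN(C(=O)[C@@H]2CN(C(C)(C)C)C[C@H]2c2ccc(F)cc2F)CC1)C(=O)c1cnn(C(C)C)c1` carries the change (1-isopropyl-1H-pyrazol-4-yl in place of pyridazin-3-yl on a carbonyl carbon). Going by the values given here, no measured step exchanges one aryl group for another on this carbonyl carbon; the measured steps only show that the carbonyl-bound aryl of compound 3 sits well below the acetyl and methylsulfonyl analogues. The step of a 1.3-fold higher number from compound 3 to compound 4 (0.12 log units; within the scatter) is therefore expected to stay within the scatter or a little beyond it. For compound 4 the estimate in this assay is 650 nM, with a range from 200 nM to 2500 nM.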

Compound 4, half-maximal effective concentration: 1000 nM
Estimate against measurement, compound 4: 1.5-fold (0.19 log units) below; measured number inside the range.
By their numbers in this assay, from the lowest: compound 3; then compound 4; then compound 1. At a limit, above all of these: compound 2.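

In this assay, this carbonyl carbon proves sensitive to the exchange of one aromatic ring for another, with a 2.0-fold higher number from compound 3 to compound 4 (0.31 log units; beyond the scatter). The gain over acetyl survives this exchange, though it is smaller, with a 2.8-fold lower number from compound 1 to compound 4 (0.45 log units; beyond the scatter). Against methylsulfonyl, an at least 5.0-fold lower number from compound 2 to compound 4 (0.69 log units; beyond the scatter) is only a floor, since compound 2 stands at a limit: the limit of > 5000 nM in this assay, at which 1 of the 4 values shown sits.

The compounds shown do not separate the change of ring from the added isopropyl. A 1-methyl-1H-pyrazol-4-yl group or an unsubstituted pyrazol-4-yl group on this carbonyl carbon would address that, and a phenyl group would show whether the ring nitrogens matter.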